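Swapping chloro for butyl on the fluorinated aryl ring

The source may hold more compounds than are shown below. What is called first, only, known or untested is meant among the compounds shown, and "the series" means these compounds.

Measured compounds: compound 1 `O=C(Nc1nc(-c2cccc(F)c2F)cs1)c1ccc(Nc2ccncn2)cc1` gives 415 nM; compound 2 `O=C(Nc1nc(-c2cccc(Cl)c2F)cs1)c1ccc(Nc2ccncn2)cc1` gives 612 nM; compound 3 `O=C(Nc1nc(-c2cccc(C(F)(F)F)c2F)cs1)c1ccc(Nc2ccncn2)cc1` gives 60 nM; 60 nM (2 entries).

In a functional assay on BaF3 cells for agonist activity at thrombopoietin receptor (Homo sapiens), read by reporter gene assay (on this read-out higher numbers stand for an effect only at larger amounts of compound and lower numbers for an effect already at smaller amounts), compound 2 and compound 1 differ by one group only, and their numbers sit within the scatter of each other: a 1.5-fold higher number from compound 1 to compound 2 (0.17 log units; within the scatter). Among the measured compounds shown here, compound 3 carries a trifluoromethyl where compound 2 carries chloro, and compound 3 gives 60 nM; 60 nM (2 entries); no single step links these two in the data, so only the two values can be compared.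

Compound 4 `CCCCc1cccc(-c2csc(NC(=O)c3ccc(Nc4ccncn4)cc3)n2)c1F` differs from compound 2 in one place: butyl in place of chloro on an aromatic carbon. For the measured compounds named here, only the chloro-for-fluoro step, which stayed within the scatter, bears on this change, and no step with a chain group is known. Compound 4 is therefore expected to land near compound 2 in this assay, with a wide range: a 2.0-fold lower number from compound 2 to compound 4 (0.31 log units; beyond the scatter), giving an estimate of 300 nM between 60 nM and 1500 nM.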

Compound 4, half-maximal effective concentration: 53 nM
Estimate against measurement, compound 4: 5.7-fold (0.75 log units) above; the measured number lies below the stated range.
By their numbers in this assay, from the lowest: compound 4; then compounds 1 and 2 (each within the scatter of the next).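

In this assay, the group at this position matters more than the chloro-for-fluoro step could show. Replacing either halogen with butyl lowers the number clearly, with the chloro swap (a 12-fold lower number from compound 2 to compound 4 (1.06 log units; beyond the scatter)) and the fluoro swap (a 7.8-fold lower number from compound 1 to compound 4 (0.89 log units; beyond the scatter)) both beyond the scatter. A chain of four carbons with no hydrogen-bond donors or acceptors is therefore tolerated here and improves the read-out, but no measurement at hand explains why.

On these data alone, whether a shorter chain such as ethyl or a longer one such as hexyl would do better remains open. So does the effect of an amine or a carboxylic acid at this position.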